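Benzyl in place of hydrogen on the benzimidazole-type nitrogen

This account rests on a few compounds, and the source may have more. Where it says the series, first, only, none or still open, it means among the compounds named here.

Measured compounds:
compound 1, `Cn1c(CN2CCN(c3ncc(C(F)(F)F)cc3Cl)CC2)nc2ccccc21`, 79.4 nM
compound 2, `FC(F)(F)c1ccc(Cl)nc1N1CCN(Cc2nc3ccccc3[nH]2)CC1`, 12600 nM
compound 3, `CCCn1c(CN2CCN(c3ncc(Cl)cn3)CC2)nc2ccccc21`, 794 nM

In an assay on CHO cells with metabotropic glutamate receptor 2 (Homo sapiens) as the target, read by FLIPR (on this read-out lower numbers stand for an effect already at smaller amounts and higher numbers for an effect only at larger amounts of compound), compound 2 gives the highest of the three numbers, far beyond the usual scatter from both compound 3 and compound 1. Compound 4, `FC(F)(F)c1ccc(Cl)nc1N1CCN(Cc2nc3ccccc3n2Cc2ccccc2)CC1`, is not yet measured. It differs from compound 2 in one place only: benzyl in place of hydrogen on an aromatic nitrogen. Compounds 1 and 3, which carry a group on that same aromatic nitrogen but also differ from compound 2 elsewhere, give much lower numbers in this assay, so a single shared cause cannot be read off. Still, a large step toward a lower number is expected from compound 2 to compound 4, a 13-fold lower number from compound 2 to compound 4 (1.10 log units; beyond the scatter), with compound 4 estimated at 1000 nM, within 250 nM to 4000 nM.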

Compound 4, half-maximal effective concentration: 126 nM
Compound 4: middle estimate off by 7.9-fold (0.90 log units), on the high side; the whole stated range lies above it.
By their numbers in this assay, from the lowest: compounds 1 and 4 (each within the scatter of the next); then compound 3; then compound 2.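

In this assay, the aromatic nitrogen proves to be a position where one change alone moves the number a long way: benzyl in place of hydrogen gives a 100-fold lower number from compound 2 to compound 4 (2.00 log units; beyond the scatter), with the rest of the molecule unchanged. Compounds 1 and 3 could not show this, as they also differ from compound 2 elsewhere. No measurement here explains the size of this step. Still open, on these data alone, is whether other groups on this nitrogen, such as a longer chain like hexyl or a chain ending in an amine or a carboxylic acid, would give a similar step.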